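The compounds below may be only part of what the source reports. "The series", "measured", "known", "first", "only" and "open" are said of these compounds alone.

Working notes on the amide series.

Going by the values given here, compound 3 `Cc1cc(NC(=O)C2CC2)ccc1N1CCC(N2CCCC2C)C1` carries the highest of the three numbers so far in an assay on CHO cells for displacement of a labelled ligand from histamine receptor H3 (Macaca mulatta) (a higher number here means a weaker inhibitor, a lower number a stronger inhibitor), giving 17.7 nM. Nearest to it is compound 1 `Cc1cc(NC(=O)C2CCOCC2)ccc1N1CCC(N2CCCC2C)C1`, which gives 17 nM; furthest is compound 2 `Cc1cc(NC(=O)CC2CCCC2)ccc1N1CCC(N2CCCC2C)C1`, which gives 10.7 nM. None of the three is separated from another by more than the scatter: a 1.0-fold higher number from compound 1 to compound 3 (0.02 log units; within the scatter), a 1.7-fold higher number from compound 2 to compound 3 (0.22 log units; within the scatter), and a 1.6-fold lower number from compound 1 to compound 2 (0.20 log units; within the scatter). All three variations on the carbonyl carbon therefore read as flat.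

Compound 4 `Cc1cc(NC(=O)C2CCCO2)ccc1N1CCC(N2CCCC2C)C1` is the next member, not yet measured. The change from compound 3 is oxolan-2-yl in place of cyclopropyl on a carbonyl carbon. The step that bears most directly on it is the one from the oxan-4-yl amide to the cyclopropyl amide, a 1.0-fold higher number from compound 1 to compound 3 (0.02 log units; within the scatter), which was within the scatter; the step of a 1.7-fold higher number from compound 2 to compound 3 (0.22 log units; within the scatter) was likewise within the scatter. On that basis no step beyond the scatter is expected in this assay, in either direction, and the expected step is a 1.1-fold lower number from compound 3 to compound 4 (0.04 log units; within the scatter). For compound 4 the estimate is 16 nM, with a range from 7 nM to 40 nM.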

Compound 4, inhibition constant: 17 nM
Compound 4: middle estimate off by 1.1-fold (0.03 log units), on the low side, and the stated range covers the measured number.
By their numbers in this assay, from the lowest: compounds 2, 1, 4 and 3 (each within the scatter of the next).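

In this assay, oxolan-2-yl on the carbonyl carbon adds a five-membered ring with a hetero atom to the groups seen at this position, and the step from cyclopropyl stays within the scatter (a 1.0-fold lower number from compound 3 to compound 4 (0.02 log units; within the scatter)). The comparisons with the other two amides are also within the scatter (a 1.6-fold higher number from compound 2 to compound 4 (0.20 log units; within the scatter); no change at the digits printed from compound 1 to compound 4 (within the scatter)). Across these four compounds, a hydrogen-bond acceptor in the group, present in compound 1 and compound 4 and absent from compound 2 and compound 3, does not separate the numbers.

The data shown give no reason for this flat response at the carbonyl carbon. Going by these compounds, it remains open whether a group of another kind at this position, such as an aminomethyl group or a carboxylic acid, would produce a step beyond the scatter.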